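Double-bond geometry at the weak end of the series

The source may hold more compounds than are shown below. What is called first, only, known or untested is meant among the compounds shown, and "the series" means these compounds.

Values in a functional assay on P388 cells (Mus musculus) for cytotoxicity; a higher number here means a weaker inhibitor, a lower number a stronger inhibitor:
- compound 1 `COc1cc(/C=C\c2ccc3ncccc3c2)cc(OC)c1OC`: 31.6 nM
- compound 2 `COc1cc(/C=C/c2ccc3cccnc3c2)cc(OC)c1OC`: 1580 nM
- compound 3 `COc1cc(/C=C\c2ccc3nccnc3c2)cc(OC)c1OC`: 7940 nM

Compound 3 has the highest number of the three and is the weakest inhibitor here, with compound 2 nearest and compound 1 furthest away. Compound 4 `COc1cc(/C=C/c2ccc3nccnc3c2)cc(OC)c1OC` differs from it only in configuration as drawn (the two compounds have the same atoms and bonds and differ only in configuration as drawn: 1 of 1 stereo elements differ; a double bond is drawn Z in compound 3 and E in compound 4), with a double bond drawn Z in compound 3 and E in compound 4.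

Within the data shown here, no measured pair isolates this change. Compound 2, drawn E, gives 1580 nM and compound 1, drawn Z, gives 31.6 nM in this assay, but these two also differ elsewhere. With compound 3 at 7940 nM already, the expected change a 1.3-fold higher number from compound 3 to compound 4 (0.10 log units; within the scatter) stays within the scatter or leans slightly toward a weaker inhibitor. The estimate for compound 4 is 10000 nM, with an expected range of 3000 nM to 40000 nM.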

Compound 4, half-maximal inhibitory concentration: > 15800 nM
Compound 4: only a limit was reported; the forecaster's own chance of this, stated with the estimate: 25%; middle value at least 1.5-fold (0.19 log units) away from the limit.
By their numbers in this assay, from the lowest: compound 1; then compound 2; then compound 3. At a limit, above all of these: compound 4.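

Compound 3 and compound 4 give the series its first pair that isolates the double-bond geometry in this assay: the fact that compounds 3 and 4 differ only in the configuration as drawn. Compound 4 gives > 15800 nM, which is a limit and not a number. The result is an at least 1.9-fold higher number from compound 3 to compound 4 (0.29 log units; that floor lies within the scatter), so the E form shows no gain over the Z form in this pair, while the size of any loss stays undetermined.

From the compounds shown here alone, whether the same geometry change carries over to the core of compound 1 remains open. So does the effect in this assay of an amine on the shared core.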